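Swapping cyclohexyl for tert-butyl on a spirocyclic cholesterol-transporter binder

The source may hold more compounds than are shown below. What is called first, only, known or untested is meant among the compounds shown, and "the series" means these compounds.

Measured compounds:
compound 1 `CC(C)(C)c1ccc(C(=O)N2CCC3(CC2)C(=O)N(CC(=O)NCCO)CN3c2ccccc2)cc1` — 1000 nM
compound 2 `CC(C)(C)c1ccc(C(=O)N2CCC3(CC2)C(=O)N(CC(=O)NCN)CN3c2ccccc2)cc1` — 26500 nM
compound 3 `CC1(C)CC(OC(=O)CN2CN(c3ccccc3)C3(CCN(C(=O)c4ccc(C5CCCCC5)cc4)CC3)C2=O)CC(C)(C)N1` — 600 nM

All three share one core and were tested in an assay on HEK293 cells for displacement of a labelled ligand from NPC1-like intracellular cholesterol transporter 1 (Homo sapiens); on this read-out lower numbers stand for stronger inhibition and higher numbers for weaker inhibition. Compound 3 sits at the low end of the three numbers: compound 1 lies within the usual scatter of it, whereas compound 2 gives a far higher number. For the measured compounds named here, the only single-point change that has been measured is a 27-fold higher number from compound 1 to compound 2 (1.42 log units; beyond the scatter), and that change sits at the opposite end of the molecule from the one now in question.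

Compound 4 `CC1(C)CC(OC(=O)CN2CN(c3ccccc3)C3(CCN(C(=O)c4ccc(C(C)(C)C)cc4)CC3)C2=O)CC(C)(C)N1` is not yet measured. It differs from compound 3 in one place: tert-butyl in place of cyclohexyl on an aromatic carbon. Going by the values given here, no measured pair isolates this particular swap, so the step from compound 1 to compound 2 gives no direct guidance. The closest hint comes from compound 1, which also carries tert-butyl on that aromatic carbon but differs from compound 3 at the other end as well: in this assay compound 1 gives 1000 nM. Compound 3 gives 600 nM, and the two values lie within the scatter. On that basis the expected step of a 1.5-fold higher number from compound 3 to compound 4 (0.18 log units; within the scatter) is small and could go either way, so compound 4 is estimated at 900 nM, with a likely range from 300 nM to 3000 nM.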

Compound 4, half-maximal inhibitory concentration: 1300 nM
The estimate for compound 4 lay 1.4-fold (0.16 log units) below the measured number, within the range that was stated.
By their numbers in this assay, from the lowest: compounds 3, 1 and 4 (each within the scatter of the next, the first and the last beyond it); then compound 2.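

In this assay the swap of cyclohexyl for tert-butyl on the aromatic carbon now has a measurement of its own: the change is a 2.2-fold higher number from compound 3 to compound 4 (0.34 log units; beyond the scatter) and is modest, so at this position the carbon ring can give way to the smaller group with no ring at a limited cost. At the other end of the molecule, with tert-butyl held fixed, the change is a 1.3-fold higher number from compound 1 to compound 4 (0.11 log units; within the scatter) and so (2,2,6,6-tetramethylpiperidin-4-yl)oxy and (2-hydroxyethyl)amino on the carbonyl carbon cannot be told apart. The same carbonyl carbon bearing (aminomethyl)amino gives a very different result, as the change is a 20-fold lower number from compound 2 to compound 4 (1.31 log units; beyond the scatter) and is large, which leaves compound 2 alone at the high end of these four numbers.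

Going by these compounds, whether a phenyl or an isopropyl on that aromatic carbon, or a hydroxyl on the carbonyl carbon giving a carboxylic acid, would keep the number close to these values remains open. Nothing available here gives a reason for any of these steps.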